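The source may hold more compounds than are shown below. What is called first, only, known or untested is meant among the compounds shown, and "the series" means these compounds.

Compounds measured so far:
compound 1 `Nc1scc(CN2CCN(c3ccccc3F)CC2)c1C(=O)c1ccc(Cl)cc1` — 4%
compound 2 `Nc1scc(CN2CCN(c3c(F)cc(F)cc3F)CC2)c1C(=O)c1ccc(Cl)cc1` — 0%

In an assay on CHO cells for displacement of a labelled ligand from adenosine receptor A1 (Homo sapiens), read by scintillation counting, with a stated time of 120 min, tested at 10 uM (on this read-out higher numbers stand for more inhibition at the one concentration tested (going by the name of the read-out) and lower numbers for less inhibition), compound 1 gives 4% and compound 2 gives 0%. Within the data shown here, the one step, a number 4 percentage points lower from compound 1 to compound 2 (within the scatter), is within the scatter, so compound 2 stands at the lower of the two numbers without any real separation from compound 1.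

Compound 3 `Nc1scc(CN2CCN(c3cc(Cl)ccc3Cl)CC2)c1C(=O)c1ccc(Cl)cc1` is not yet measured. The change is 2,5-dichlorophenyl in place of 2,4,6-trifluorophenyl on an amine nitrogen in a ring. Among the measured compounds shown here, the only step that bears on it, a number 4 percentage points lower from compound 1 to compound 2 (within the scatter), left the read-out flat, so no step beyond the scatter is expected. Compound 3 is expected to give 3% (range 0% to 15%), an expected step of a number 3 percentage points higher from compound 2 to compound 3 (within the scatter).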

Compound 3, a percentage reported as inhibition, at one concentration (the size of the read-out at that concentration, not a potency): 0%
Beside the measured number, compound 3's estimate is 3 percentage points above it; low and high end bracket the measured number.
By their numbers in this assay, from the lowest: compounds 2, 3 and 1 (each within the scatter of the next).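

In this assay, 2,5-dichlorophenyl in place of 2,4,6-trifluorophenyl on an amine nitrogen in a ring gives no change at the digits printed from compound 2 to compound 3 (within the scatter) and, set against the 2-fluorophenyl group, gives a number 4 percentage points lower from compound 1 to compound 3 (within the scatter) as well. Chlorine on the phenyl therefore leaves the read-out as flat as fluorine did, across a different substitution pattern at this position. No evidence on hand accounts for this flat read-out. Still open, going by these compounds, is whether a methoxy group, a primary amine or a carboxylic acid on this phenyl would move the number. Also open, on these data alone, is whether this position stays flat with another group in place of the 4-chlorophenyl ketone.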